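This account rests on a few compounds, and the source may have more. Where it says the series, first, only, none or still open, it means among the compounds named here.

Compound 1 `COC(=O)c1cc(-c2cccc(NC(=O)c3ccc(/C=C/C(=O)c4ccccc4)cc3)c2)on1`: > 50 ug/mL
Compound 2 `COC(=O)c1cc(-c2cccc(NC(=O)c3ccc(/C=C/C(=O)c4cccc(C(F)(F)F)c4)cc3)c2)on1`: > 20 ug/mL

Both compounds were tested in an ADME assay on Vero cells (Chlorocebus sabaeus) for cytotoxicity, read by MTT assay, with a stated time of 72 h; a higher number here means that more compound is tolerated, a lower number that less compound is tolerated. Compound 1 gives > 50 ug/mL, which is a limit of the assay and not a number. Compound 2 gives > 20 ug/mL, likewise a limit rather than a number. Compound 2 thus stands at the limit of > 20 ug/mL in this assay, at which 1 of the 2 values shown sits. Compound 1 stands at the limit of > 50 ug/mL in this assay, at which 1 of the 2 values shown sits. Among the compounds with values here, the one measured step, a step that the two limits leave unreadable from compound 1 to compound 2, is unreadable: both of its values are limits, so neither its direction nor its size can be told.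

Compound 3 `COC(=O)c1cc(-c2cccc(NC(=O)c3ccc(/C=C/C(=O)c4ccc(C)cc4)cc3)c2)on1` has not yet been measured. Its change from compound 2 is 4-methylphenyl in place of 3-(trifluoromethyl)phenyl on a carbonyl carbon. Within the data shown here, the only step that touches this part of the molecule is a step that the two limits leave unreadable from compound 1 to compound 2, and it gives no readable size, so there is no measured basis for expecting a shift beyond the scatter in this assay in either direction. Compound 3 is therefore expected to be tolerated much as compound 2 is, and the step that the limit leaves unreadable from compound 2 to compound 3 is an estimate of no real change. The estimate for compound 3 in this assay is 50 ug/mL, within a range from 20 ug/mL to 100 ug/mL, and it may well again come back as a limit.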

Compound 3, half-maximal cytotoxic concentration: > 80 ug/mL
Compound 3: a limit, no number; the forecaster's own chance of this, stated with the estimate: 70%; middle value at least 1.6-fold (0.20 log units) from the limit.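

Compound 3, like compound 1 and compound 2, has only a limit of the assay and not a number in this assay, and neither its step from compound 1 nor its step from compound 2 can be read. The compounds shown leave open at what concentration any of them harms the cells, and whether the trifluoromethyl or methyl group changes that concentration at all.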